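Swapping a bicyclic heteroaryl for dichlorophenyl on a shared core

The source may hold more compounds than are shown below. What is called first, only, known or untested is meant among the compounds shown, and "the series" means these compounds.

Of the compounds shown here, three have been tested in a functional assay on MV4-11 cells (Homo sapiens) for cytotoxicity, read by colorimetric assay and MTT assay, with a stated time of 3 days, tested at 1 uM; on this read-out lower numbers stand for a stronger effect and higher numbers for a weaker effect at the one concentration tested. Compound 1 `Cc1ccccc1-n1cc(-c2ccccc2)c(-c2ccc3c(c2)NC(=O)CO3)n1` gives 99.4%, compound 2 `O=C1COc2ccc(-c3nn(-c4ccc(Br)cc4)cc3-c3ccccc3)cc2N1` gives 108%, and compound 3 `O=C1COc2ccc(-c3[nH]c(-c4c[nH]c5ncccc45)nc3-c3ccccc3)cc2N1` gives 111%. Compound 3 thus sits above compound 1 by more than the scatter, while its gap to compound 2 lies within the scatter, so none of the three shows a marked effect at the single concentration tested.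

Compound 4 `O=C1COc2ccc(-c3[nH]c(-c4ccc(Cl)cc4Cl)nc3-c3ccccc3)cc2N1` is compound 3 with a change on an aromatic carbon: a group of 8 heavy atoms (6 carbon, 2 chlorine; one six-membered aromatic ring of carbon only) in place of a group of 9 heavy atoms (7 carbon, 2 nitrogen; one five-membered aromatic ring with 1 hetero atom, one six-membered aromatic ring with 1 hetero atom), on an aromatic carbon. Among the compounds with values here, the only measured step, a number 8.6 percentage points higher from compound 1 to compound 2 (within the scatter), concerns a different position on a different core and was within the scatter; no step touches the carbon between two ring nitrogen atoms where the 2,4-dichlorophenyl enters. Within the data shown here, with every number so far near the level of no effect, the expected step of a number 11 percentage points lower from compound 3 to compound 4 (beyond the scatter) is none beyond the scatter. Compound 4 is therefore estimated at 100% in this assay, with a range from 85% to 115%.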

Compound 4, a percentage reported as activity, at one concentration (the size of the read-out at that concentration, not a potency): 109%
Estimate against measurement, compound 4: 9 percentage points below; measured number inside the range.
By their numbers in this assay, from the lowest: compounds 1, 2, 4 and 3 (each within the scatter of the next, the first and the last beyond it).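

On the aromatic carbon between two ring nitrogen atoms, 2,4-dichlorophenyl replaces the group with two aromatic rings, and this assay records a number 2 percentage points lower from compound 3 to compound 4 (within the scatter). Within the data shown here, this gives the first reading at this position: a carbon-only ring bearing two chlorines, with 0 hydrogen-bond donors and 0 hydrogen-bond acceptors, cannot be told apart here from a group with 1 of each, and neither compound shows a marked effect at the single concentration tested. No available evidence bears on this result.

The compounds shown leave open whether a much smaller substituent on this carbon, such as an amine or a carboxylic acid, would give a different number. They also leave open whether compound 3 or compound 4 would act on these cells at a higher concentration.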